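The source may report more compounds than this note shows. Statements on the series, on what has been measured and on what is new or still open speak of the compounds shown alone.

Compound 1 `CCOC(=O)CCCCCOc1cccc(CN(C(=O)c2ccccc2)C(C)C)c1` in an ADME assay on HEK293 cells (Homo sapiens) for cytotoxicity, read by CellTiter-Glo and resazurin assay, with a stated time of 72 h (a lower number here means that less compound is needed, a higher number that more compound is needed for the effect), gives > 26000 nM, which is a limit of the assay rather than a number.
Compound 2 `CCOC(=O)CCCCCOc1cccc(CN(C(=O)c2ccc(-c3cccnc3)cc2)C(C)C)c1` gives > 26000 nM, also a limit.
Compound 3 `CCOC(=O)CCCCCOc1cccc(CN(C(=O)c2ccc(-c3ccc4[nH]ccc4c3)cc2)C(C)C)c1` gives > 26000 nM, again a limit.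

Compound 3 therefore stands only at a limit, and the same holds for all three values shown (the limit of > 26000 nM in this assay, at which 3 of the 3 values shown sit). The step to compound 4 `CCOC(=O)CCCCCOc1cccc(CN(C(=O)c2ccc(-c3cccc([N+](=O)[O-])c3)cc2)C(C)C)c1` is 3-nitrophenyl in place of 1H-indol-5-yl on an aromatic carbon. Among the measured compounds shown here, the steps that bear on it, a step that the two limits leave unreadable from compound 1 to compound 3 and a step that the two limits leave unreadable from compound 2 to compound 3, cannot be read in size. Every value involved is a limit, so no direction or size of step in this assay can be drawn from them. Compound 4 is expected to give 26000 nM, within 10000 nM and 60000 nM, most likely again as a limit. The expected step is a number no higher from compound 3 to compound 4 (the limit leaves the size open).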

Compound 4, half-maximal effective concentration: > 26000 nM
Compound 4: only a limit was reported; the forecaster's own chance of this, stated with the estimate: 80%; the middle value lies on the limit itself.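

Among the compounds shown here, compound 4 gives > 26000 nM as a limit of the assay, so no step to it from compound 1, compound 2 or compound 3 can be read. Left open is whether any of these groups changes the value in this assay at all, and by how much: the limit of > 26000 nM in this assay, at which 4 of the 4 values shown sit.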